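This account rests on a few compounds, and the source may have more. Where it says the series, first, only, none or still open, it means among the compounds named here.

Compound 1 `NCCCCN(C[C@@H]1CN(C(=O)c2ccco2)CCN1)[C@H]1CCCc2cccnc21` is the stronger of the two measured compounds in a functional assay on Chem-1 cells for antagonist activity at C-X-C chemokine receptor type 4 (Homo sapiens), read by calcium flux (a higher number here means a weaker inhibitor, a lower number a stronger inhibitor), where compound 1 gives 35 nM. Its only measured companion, compound 2 `NCCCCN(C[C@H]1CN(C(=O)Nc2ccccc2)CCN1)[C@H]1CCCc2cccnc21`, gives 21000 nM in this assay, a far higher number that lies well beyond the scatter; the two structures differ in more than one place, so the pair says nothing about any single change.

Compound 3 `NCCCCN(C[C@@H]1CNCCN1)[C@H]1CCCc2cccnc21` has not yet been measured in this assay. It differs from compound 1 in one place: hydrogen in place of (furan-2-yl)carbonyl on an amine nitrogen in a ring. Among the compounds with values here, no measured pair shows this change on this core. From the compounds shown here alone, because the furan-2-ylcarbonyl group of compound 1 is the only substituent on that ring nitrogen among the measured compounds, and because compound 2 with a different substituent and a different configuration gives 21000 nM, the weight of the group at that position is unknown. The writer expects the step from compound 1 to compound 3 to be a moderate loss, a 4.3-fold higher number from compound 1 to compound 3 (0.63 log units; beyond the scatter), in this assay. Compound 3 is therefore estimated at 150 nM, with a range from 30 nM to 1000 nM.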

Compound 3, half-maximal inhibitory concentration: 1200 nM
For compound 3 the middle estimate is 8.0-fold (0.90 log units) below the measured one; the measured number lies above the stated range.
By their numbers in this assay, from the lowest: compound 1; then compound 3; then compound 2.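

In this assay, putting hydrogen in place of (furan-2-yl)carbonyl on the amine nitrogen in the ring gives a 34-fold higher number from compound 1 to compound 3 (1.54 log units; beyond the scatter), so the step is large. Within the data shown here, until now no pair differed at this position alone, and this step shows that the position is far from indifferent to what it carries: much of the strength of compound 1 goes when the group leaves, although compound 3, with only hydrogen on that nitrogen, still gives a measurable 1200 nM. Nothing in the data at hand explains why the step is this large.

This one step cannot tell whether the strength of compound 1 depends on the furan ring, on the carbonyl, or on both together; an acetyl group, a benzoyl group or a simple methyl on that nitrogen would begin to separate these. It also leaves open whether the same step would hold with the other configuration at the ring atom that bears the large group, and compound 2, which differs from compound 1 in more than one place, cannot be read on either question.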